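Lipophilicity notes on compounds 1 to 4

The source may report more compounds than this note shows. Statements on the series, on what has been measured and on what is new or still open speak of the compounds shown alone.

compound 1 `O=C(NC1(C(=O)NO)CCN(Cc2ccccc2)CC1)c1ccc(C#Cc2ccccc2)cc1` — > 3
compound 2 `O=C(NC1(C(=O)NO)CCSCC1)c1ccc(C#Cc2ccccc2)cc1` — > 3
compound 3 `COCCNC(=O)C[C@H](NC(=O)c1ccc(C#Cc2ccccc2)cc1)C(=O)NO` — 2

In a physicochemical assay for lipophilicity (on this read-out lower numbers stand for lower lipophilicity and higher numbers for higher lipophilicity), compound 1 reaches only the limit > 3. Compound 2 likewise stops at the limit > 3 in this assay. For the measured compounds named here, compound 3 is the only compound with a number in this assay, giving 2, and so stands apart from the limit of > 3 in this assay, at which 2 of the 3 values shown sit.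

Compound 4 `CS(=O)(=O)C[C@H](NC(=O)c1ccc(C#Cc2ccccc2)cc1)C(=O)NO` has not yet been measured in this assay. It differs from compound 3 by methylsulfonyl in place of (2-methoxyethyl)carbamoyl on a saturated chain carbon, two bonds along the chain from an amide-type nitrogen and a carbonyl carbon. Going by the values given here, no measured pair shows this change, so its size is open. For compound 4 a value of 1.7 is expected in this assay, with a range from 1.1 to 2.3. The expected step of a number 0.30 log units lower from compound 3 to compound 4 (within the scatter) is a small one downward, of a size at the edge of the usual scatter rather than clearly beyond it.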

Compound 4, distribution coefficient: 2
For compound 4 the middle estimate is 0.30 log units below the measured one; measured number inside the range.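

In this assay, for the compounds shown here, the first pair at this position shows no change at the digits printed from compound 3 to compound 4 (within the scatter). This carbon therefore takes methylsulfonyl in place of (2-methoxyethyl)carbamoyl with no readable shift, even though the entering group has fewer heavy atoms and no hydrogen-bond donor. The result covers this one change only and gives no trend for the position.

On these data alone, whether an amine or a carboxylic acid on this carbon would read the same remains open. Compound 1 and compound 2 each stand at a limit and not at a number, so steps to them cannot be read: the limit of > 3 in this assay, at which 2 of the 4 values shown sit.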